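The source may hold more compounds than are shown below. What is called first, only, known or untested is meant among the compounds shown, and "the series" means these compounds.

Measured in a physicochemical assay for solubility, measured as kinetic solubility; on this read-out lower numbers stand for lower solubility and higher numbers for higher solubility:
- Compound 1 `O=C(N[C@@H](CO)c1cccc(Cl)c1)[C@H]1CC(F)(F)CC[C@@H]1c1ccccc1` gives 318000 nM
- Compound 2 `CS(=O)(=O)c1cccc(CNC(=O)c2cc(C(F)(F)F)ccc2Sc2ccccc2)c1` gives 34000 nM
- Compound 3 `O=C(N[C@@H](CO)c1ccccc1)[C@H]1CC(F)(F)CC[C@@H]1c1ccccc1` gives 332000 nM

Compound 3 (332000 nM) stands level with compound 1 (318000 nM) within the scatter, and both numbers lie well above that of compound 2 (34000 nM).

Compound 4 `C[C@H](NC(=O)[C@H]1CC(F)(F)CC[C@@H]1c1ccccc1)c1ccccc1` differs from compound 3 in one place (hydrogen in place of hydroxy on a saturated chain carbon, two bonds along the chain from an amide-type nitrogen and an aromatic carbon): hydrogen in place of hydroxy on a saturated chain carbon, two bonds along the chain from an amide-type nitrogen and an aromatic carbon, or hydroxymethyl to methyl.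

Among the measured compounds shown here, the only measured single-place step (a 1.0-fold higher number from compound 1 to compound 3 (0.02 log units; within the scatter)) is hydrogen in place of chloro on an aromatic carbon. It lies within the scatter and concerns a different change, so it bears only weakly here. For the measured compounds named here, no measured pair removes the hydroxy. Compound 2 (34000 nM) also carries no hydroxy but differs from compound 3 in much else, which makes it poor guidance.

A moderate move to a lower number is therefore expected in this assay, with low confidence. The estimated change is a modest one (a 2.8-fold lower number from compound 3 to compound 4 (0.44 log units; beyond the scatter)). Compound 4 is estimated at 120000 nM (expected range 35000 nM to 320000 nM).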

Compound 4, solubility: 25000 nM
The estimate for compound 4 lay 4.8-fold (0.68 log units) above the measured number, and the stated range ends above it.
By their numbers in this assay, from the lowest: compounds 4 and 2 (each within the scatter of the next); then compounds 1 and 3 (each within the scatter of the next).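

In this assay hydrogen in place of hydroxy on a saturated chain carbon, two bonds along the chain from an amide-type nitrogen and an aromatic carbon, gives a 13-fold lower number from compound 3 to compound 4 (1.12 log units; beyond the scatter) and marks hydroxymethyl to methyl as a large step at this place. The other single-place step, a 1.0-fold higher number from compound 1 to compound 3 (0.02 log units; within the scatter) for hydrogen in place of chloro on an aromatic carbon, lies within the scatter, so among the compounds shown only this chain position moves the read-out beyond it. No measurement at hand accounts for the size of this step.

On these data alone, only hydroxymethyl and methyl are compared at this carbon, so it stays open whether other groups there would keep the higher number. Methoxymethyl, aminomethyl or a carboxylic acid at the same carbon would test this, and the chloro step is read only with the hydroxy present.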